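This account rests on a few compounds, and the source may have more. Where it says the series, first, only, none or still open, it means among the compounds named here.

Within the data shown here, in a functional assay on U-937 cells (Homo sapiens) for inhibition, read by MTT assay, with a stated time of 48 h (a lower number here means a stronger inhibitor, a higher number a weaker inhibitor), compound 1 `O=C1Nc2ccc(Br)cc2C1(O)c1c[nH]c2ccccc12` gives 19.3 ug/mL and has the lower of the two numbers measured so far, while compound 2 `Cc1ccc2c(c1)C(O)(c1c[nH]c3ccccc13)C(=O)N2` gives 83.4 ug/mL as the higher one. Compound 3 `O=C1Nc2ccc(Br)cc2C1(O)c1c[nH]c2ccc(Br)cc12` has not yet been measured and shares the core of compound 1 with a single change (bromo in place of hydrogen on an aromatic carbon), namely bromo in place of hydrogen on an aromatic carbon of a six-membered aromatic ring of carbon only, part of a fused or bridged system of two rings. Among the measured compounds shown here, the only measured step that bears on this is the modest one of a 4.3-fold higher number from compound 1 to compound 2 (0.64 log units; beyond the scatter) with methyl in place of bromo on an aromatic carbon. That step lies elsewhere in the molecule, so it is only a loose guide, though there the compound carrying bromo has the lower number. For the measured compounds named here, no measured compound shows what a second bromo does. A small move towards a lower number is therefore expected, possibly not beyond the usual scatter. The estimated step is a 1.6-fold lower number from compound 1 to compound 3 (0.21 log units; within the scatter) and remains only an expectation. For compound 3 the estimated value is 12 ug/mL with an expected range from 5 ug/mL to 30 ug/mL in repeat measurements.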

Compound 3, half-maximal inhibitory concentration: 43.3 ug/mL
Beside the measured number, compound 3's estimate is 3.6-fold (0.56 log units) below it; the measured number lies above the stated range.
By their numbers in this assay, from the lowest: compound 1; then compounds 3 and 2 (each within the scatter of the next).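

In this assay, putting bromo in place of hydrogen on an aromatic carbon of a six-membered aromatic ring of carbon only, part of a fused or bridged system of two rings, gives a 2.2-fold higher number from compound 1 to compound 3 (0.35 log units; beyond the scatter). At this position, then, a second bromo goes with weaker inhibition, and the change is modest but larger than the difference expected between repeat measurements. The earlier step, a 4.3-fold higher number from compound 1 to compound 2 (0.64 log units; beyond the scatter), compared bromo with methyl elsewhere in the molecule and left bromo with the lower number, so the new result shows that this advantage does not simply carry over to another aromatic carbon, and nothing available explains the loss.

Among these compounds, it remains open whether the same bromo step would appear without the bromo already present in compound 1, since the only comparison here has that first bromo in place. Also unknown is how fluoro, methoxy, an amine or a carboxylic acid would compare with hydrogen and bromo on this same carbon, and whether any of them would give a lower number than compound 1.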